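Halogenated phenol exchange across two related macrocyclic cores

The source may report more compounds than this note shows. Statements on the series, on what has been measured and on what is new or still open speak of the compounds shown alone.

Measured compounds:
compound 1 `CC[C@H](C)[C@H]1C(=O)N[C@H](Cc2cc(Cl)c(O)c(Cl)c2)C(=O)N[C@@H](C(C)(C)O)C(=O)O[C@H](c2ccccc2)[C@H](C)/C=C/C=C(\C)[C@H](OC)C[C@@H]2O[C@@]2(C)C(=O)N1C` with 3.36 nM
compound 2 `CC[C@H](C)[C@H]1C(=O)N[C@H](Cc2ccc(O)c(Br)c2)C(=O)N[C@@H](C(C)(C)O)C(=O)O[C@H](c2ccccc2)[C@H](C)/C=C/C=C(\C)[C@H](OC)C[C@@H]2O[C@@]2(C)C(=O)N1C` with 2.98 nM
compound 3 `CC[C@H](C)[C@H]1C(=O)N[C@H](Cc2cc(Cl)c(O)c(Cl)c2)C(=O)N[C@@H](C(C)C)C(=O)O[C@H](c2ccccc2)[C@H](C)/C=C/C=C(\C)[C@H](OC)C/C=C(\C)C(=O)N1C` with 104 nM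

In a functional assay on HepG2 cells (Homo sapiens) for antiproliferative activity (on this read-out higher numbers stand for weaker inhibition and lower numbers for stronger inhibition), compound 1 and compound 2 give numbers that lie close together. Their structures differ by one change, (3-bromo-4-hydroxyphenyl in place of 3,5-dichloro-4-hydroxyphenyl on a saturated chain carbon bound to a saturated ring carbon), and that change produced a 1.1-fold lower number from compound 1 to compound 2 (0.05 log units; within the scatter). Compound 3 stands apart: it shares the halogenated phenol of compound 1 but rests on a different core, and how the two cores differ is not broken down here. In this assay compound 3 gives 104 nM, the highest number of the three.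

Compound 4 `CC[C@H](C)[C@H]1C(=O)N[C@H](Cc2ccc(O)c(Br)c2)C(=O)N[C@@H](C(C)C)C(=O)O[C@H](c2ccccc2)[C@H](C)/C=C/C=C(\C)[C@H](OC)C/C=C(\C)C(=O)N1C` is not yet measured. It differs from compound 3 by the same change, (3-bromo-4-hydroxyphenyl in place of 3,5-dichloro-4-hydroxyphenyl on a saturated chain carbon bound to a saturated ring carbon), that separates compound 2 from compound 1. Since that change in this assay was within the scatter from compound 1 to compound 2, compound 4 is expected to show a step of about a 1.1-fold lower number from compound 3 to compound 4 (0.04 log units; within the scatter), essentially unchanged. The value of compound 4 in this assay is therefore estimated at 95 nM, with a likely range from 40 nM to 250 nM.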

Compound 4, half-maximal inhibitory concentration: 53.7 nM
For compound 4 the middle estimate is 1.8-fold (0.25 log units) above the measured one, and the stated range covers the measured number.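

On the second core, in this assay, replacing 3,5-dichloro-4-hydroxyphenyl with 3-bromo-4-hydroxyphenyl gave a 1.9-fold lower number from compound 3 to compound 4 (0.29 log units; within the scatter), so this step is again small. Set side by side, the steps on the two cores do not differ, and the exchange carried over with no detectable change in its size: the same change on two cores in this assay, a 1.1-fold lower number (0.05 log units; within the scatter) from compound 1 to compound 2 and a 1.9-fold lower number (0.29 log units; within the scatter) from compound 3 to compound 4, 1.7-fold (0.23 log units) apart, within the scatter of two such steps. Among the compounds shown here, this rests on one matched pair per core, so it shows only that the exchange behaves alike on these two cores, not that it would do so on any other core, and it does not reveal which part of the cores sets their behaviour.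

The compounds shown leave open how either core would respond to a plain phenyl, a 4-methoxyphenyl or a 3-iodo-4-hydroxyphenyl group in the same place. From the compounds shown here alone, it also remains open whether the agreement between the two steps would hold for a phenol bearing an amine or a carboxylic acid.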